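The source may hold more compounds than are shown below. What is called first, only, known or untested is meant among the compounds shown, and "the series" means these compounds.

Series notes. In an ADME assay on HeLa cells (Homo sapiens) for cytotoxicity, read by MTT assay (on this read-out higher numbers stand for weaker inhibition and lower numbers for stronger inhibition), compound 1 `N#Cc1c(-c2ccccc2O)c(C#N)c(=O)n(/N=C/c2cn(-c3ccccc3)nc2-c2ccccc2)c1N` gives > 200 ug/mL, which is a limit of the assay and not a number. Compound 2 `COc1cc(-c2c(C#N)c(N)n(/N=C/c3cn(-c4ccccc4)nc3-c3ccccc3)c(=O)c2C#N)cc(OC)c1OC` in this assay likewise returns only a limit, > 200 ug/mL. Among the compounds with values here, the one step among the measured pair, a step that the two limits leave unreadable from compound 1 to compound 2, cannot be sized because of the limit of > 200 ug/mL in this assay, at which 2 of the 2 values shown sit. Compound 2 thus stands at the limit, with no measured number beside it to order it against.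

Compound 3 `N#Cc1c(-c2ccccc2Br)c(C#N)c(=O)n(/N=C/c2cn(-c3ccccc3)nc2-c2ccccc2)c1N` is not yet measured; it differs from compound 2 by 2-bromophenyl in place of 3,4,5-trimethoxyphenyl on an aromatic carbon. Within the data shown here, the only measured step concerns a change at the same carbon, but it gives no readable size or direction because of the limit of > 200 ug/mL in this assay, at which 2 of the 2 values shown sit. In this assay compound 3 is therefore expected to give about 250 ug/mL, within a range from 100 ug/mL to 500 ug/mL, and most likely to be reported as a limit once more. The step that the limit leaves unreadable from compound 2 to compound 3 is accordingly estimated to stay within the scatter.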

Compound 3, half-maximal inhibitory concentration: > 200 ug/mL
Compound 3 gave a limit, no number; the forecaster's own chance of this, stated with the estimate: 80%; the middle value does not contradict the limit.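

Within the data shown here, compound 3 also returns only a limit in this assay, so no step among compound 1, compound 2 and compound 3 can be read: the limit of > 200 ug/mL in this assay, at which 3 of the 3 values shown sit.

Left open is whether the 2-hydroxyphenyl, 3,4,5-trimethoxyphenyl and 2-bromophenyl compounds differ at all in this assay, and which change to the shared core, if any, would yield a measured number.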